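Anilinopyrimidine series: growth inhibition of breast cancer cells

This account rests on a few compounds, and the source may have more. Where it says the series, first, only, none or still open, it means among the compounds named here.

Working notes on three measured compounds and one awaiting measurement, all read in a functional assay on MCF7 cells (Homo sapiens) for inhibition, read by CCK-8 assay, with a stated time of 48 h; a lower number here means a stronger inhibitor of growth, a higher number a weaker inhibitor of growth.

Compound 1 `Cc1ccccc1Nc1nc(NCc2ccco2)ncc1Cl` reaches only the limit of this assay, > 100000 nM, and no number can be placed on it. Compound 2 `Cc1ccccc1Nc1nc(Nc2ccc(N3CCCCC3)cn2)ncc1Cl` gives 21400 nM. Compound 3 `CN1CCN(c2ccc(Nc3ncc(Cl)c(NCc4ccc(C(F)(F)F)cc4)n3)nc2)CC1` gives 28400 nM, the higher of the two numbers available, though its gap to compound 2 lies within the usual scatter, so the two cannot be ordered. One further point should be noted: the limit of > 100000 nM in this assay, at which 1 of the 3 values shown sits.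

Compound 4 `Cc1cc(C)c(Nc2nc(Nc3ccc(N4CCN(C)CC4)cn3)ncc2Cl)c(C)c1` differs from compound 3 by one change: 2,4,6-trimethylphenyl in place of 4-(trifluoromethyl)benzyl on a nitrogen on an aromatic ring. Among the measured compounds shown here, no measured pair in the set shows this exact change, so no step size can be read off. Compound 4 shares its second aromatic amine with compound 2, whose value 21400 nM sits within the scatter of compound 3, so the change is expected to bring compound 4 within or near the scatter of compound 3, with the estimated step of a 1.9-fold lower number from compound 3 to compound 4 (0.28 log units; within the scatter) leaning toward a lower number. Compound 4 is therefore estimated at 15000 nM, between 4000 nM and 60000 nM.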

Compound 4, concentration for 50% growth inhibition: 9470 nM
Compound 4: middle estimate off by 1.6-fold (0.20 log units), on the high side; measured number inside the range.
By their numbers in this assay, from the lowest: compound 4; then compounds 2 and 3 (each within the scatter of the next). At a limit, above all of these: compound 1.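

In this assay, among the compounds shown here, replacing 4-(trifluoromethyl)benzyl with 2,4,6-trimethylphenyl on a nitrogen on an aromatic ring gives a 3.0-fold lower number from compound 3 to compound 4 (0.48 log units; beyond the scatter) and provides the first step that can be read from a matched pair. The step lies beyond the scatter, so the number read in this assay depends on the group carried at this position, and a directly attached trimethyl-substituted phenyl group is accepted there with a modest gain. No measurement shown gives a cause for this step.

This single pair replaces the whole group at once, so it leaves open how much of the step belongs to the three methyl groups and how much to the change from benzyl to phenyl. Also open, as far as these compounds go, is how the number would move with a phenyl group carrying an amine or a carboxylic acid at this position.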